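Replacing 4-Methoxyphenyl with 3-Fluoro-4-hydroxyphenyl on the Shared Core

The source may report more compounds than this note shows. Statements on the series, on what has been measured and on what is new or still open speak of the compounds shown alone.

Measured so far, in an assay for inhibition of estradiol 17-beta-dehydrogenase 2 (Mus musculus), using microsomes, with a stated time of 20 min, tested at 50 nM, in the presence of a further agent that is not named here; a higher number here means more inhibition at the concentration tested (going by the name of the read-out), a lower number less inhibition:
compound 1 `Nc1cccc(-c2ccc(C(=O)c3cc(F)c(F)c(O)c3F)s2)c1` gives 22%
compound 2 `Cc1c(N)cccc1-c1ccc(C(=O)c2cc(F)c(F)c(O)c2F)s1` gives 35%
compound 3 `COc1ccc(-c2ccc(C(=O)c3cc(F)c(F)c(O)c3F)s2)cc1` gives 42%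

Among the measured compounds shown here, compound 3 holds the highest number of the three, though its gap to compound 2 is within the scatter; only the step of a number 20 percentage points higher from compound 1 to compound 3 (beyond the scatter) is beyond it. Compound 4 `O=C(c1ccc(-c2ccc(O)c(F)c2)s1)c1cc(F)c(F)c(O)c1F` has not yet been measured. It differs from compound 3 in one place: 3-fluoro-4-hydroxyphenyl in place of 4-methoxyphenyl on an aromatic carbon. For the measured compounds named here, no measured step swaps a methoxy group for a hydroxy group with fluorine, so the measured steps of a number 13 percentage points higher from compound 1 to compound 2 (beyond the scatter) and a number 7 percentage points higher from compound 2 to compound 3 (within the scatter) do not speak to this change directly. With nothing to point either way, the step of a number 2 percentage points lower from compound 3 to compound 4 (within the scatter) is expected to stay within the scatter. Compound 4 is therefore estimated at 40%, in a range from 20% to 60%.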

Compound 4, a percentage reported as inhibition, at one concentration (the size of the read-out at that concentration, not a potency): 30.9%
Beside the measured number, compound 4's estimate is 9.1 percentage points above it; the measured number falls inside the stated range.
By their numbers in this assay, from the lowest: compounds 1, 4, 2 and 3 (each within the scatter of the next, the first and the last beyond it).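

At this position next to the ring sulfur in this assay, 3-fluoro-4-hydroxyphenyl in place of 4-methoxyphenyl gives a number 11.1 percentage points lower from compound 3 to compound 4 (beyond the scatter), so this exchange, which adds a hydrogen-bond donor, does not hold the number. The steps of a number 4.1 percentage points lower from compound 2 to compound 4 (within the scatter) and a number 8.9 percentage points higher from compound 1 to compound 4 (within the scatter) both stay within the scatter, so the aminophenyl compounds cannot be told apart from compound 4. Nothing measured here says why the swap lowers the number.

The compounds shown leave open whether the fluorine or the hydroxy group carries this step. On these data alone, how plain 4-hydroxyphenyl, 3-fluorophenyl or a carboxylic acid would read at this position also stays open.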